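Removing One Methoxy Group from a Trimethoxyphenyl Ring

The compounds below may be only part of what the source reports. "The series", "measured", "known", "first", "only" and "open" are said of these compounds alone.

Compound 1 `COc1cc(-c2nc3cc(/C=C4\SC(=O)NC4=O)ccc3[nH]2)cc(OC)c1OC` and compound 2 `COc1ccc(-c2nc3cc(/C=C4\SC(=O)NC4=O)ccc3[nH]2)cc1OC` share the same core and differ in only one place: hydrogen in place of methoxy on an aromatic carbon. In a functional assay on PC-3 cells (Homo sapiens) for inhibition, read by MTT assay, with a stated time of 48 h (on this read-out higher numbers stand for weaker inhibition and lower numbers for stronger inhibition), compound 1 gives 12000 nM, while compound 2 gives 8720 nM. The step of a 1.4-fold lower number from compound 1 to compound 2 (0.14 log units; within the scatter) shows that the two numbers cannot be told apart by this kind of measurement.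

Compound 3 `COc1cc(CN2C(=O)S/C(=C\c3ccc4[nH]c(-c5cc(OC)c(OC)c(OC)c5)nc4c3)C2=O)cc(OC)c1OC` is built on a different core; the difference between the core of compound 3 and the core of compound 1 is not broken down here. In this assay compound 3 gives 10200 nM, a number that sits within the usual scatter of both compound 1 and compound 2.

Compound 4 `COc1ccc(-c2nc3cc(/C=C4\SC(=O)N(Cc5cc(OC)c(OC)c(OC)c5)C4=O)ccc3[nH]2)cc1OC` has not yet been measured. It differs from compound 3 by hydrogen in place of methoxy on an aromatic carbon. Among the compounds with values here, the surroundings of the changed place read the same for both pairs, so this is the same change as the one from compound 1 to compound 2, now made on the core of compound 3. For compound 4 the expected step is a 1.2-fold lower number from compound 3 to compound 4 (0.08 log units; within the scatter), because the measured step of a 1.4-fold lower number from compound 1 to compound 2 (0.14 log units; within the scatter) stayed within the scatter. Compound 4 is therefore estimated to give 8500 nM in this assay, with a likely range from 4000 nM to 18000 nM. This expectation rests on a single measured pair and on one added compound, so it remains tentative.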

Compound 4, half-maximal inhibitory concentration: > 50000 nM
Compound 4: no number, only a limit (the forecaster's own chance of this, stated with the estimate: 5%); at least 5.8-fold (0.76 log units) between middle value and limit.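

In this assay compound 4 gives > 50000 nM, which is a limit of the assay and not a number. Replacing the same methoxy group with hydrogen, which turns a 3,4,5-trimethoxyphenyl group into a 3,4-dimethoxyphenyl group, here gives an at least 4.9-fold higher number from compound 3 to compound 4 (0.69 log units; beyond the scatter), and this does not match the earlier step: the same change on two cores in this assay, a 1.4-fold lower number (0.14 log units; within the scatter) from compound 1 to compound 2 and an at least 4.9-fold higher number (0.69 log units; beyond the scatter) from compound 3 to compound 4, at least 6.7-fold (0.82 log units) apart, beyond the scatter of two such steps. So the effect of this change did not carry over from one core to the other in these two pairs, but the data do not show why, they give only a minimum for the size of the new step, and two pairs cannot set a rule for the whole series.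

The compounds shown leave open whether this position on the core of compound 3 would tolerate a different replacement for the methoxy group, such as a hydroxyl group, an amine or a fluorine atom. They also leave open whether removing the methoxy group on a third core would give a step like the small one or like the large one.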